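A few compounds are considered here, and "the series" means these few. Any claim that something is new, unique, unknown or untested is made for them only; others in the source may bear on it.

Among the compounds with values here, in a functional assay on the whole organism (strain Wistar) for inhibition, with Rattus norvegicus as the target, read by paw edema, with a stated time of 1 h, at a dose of 10 mg/kg by the intraperitoneal route (on this read-out higher numbers stand for more inhibition at the one dose given (going by the name of the read-out) and lower numbers for less inhibition), compound 2 `COc1ccc(/C=N/NC(=O)c2cccnc2Nc2cccc(C(F)(F)F)c2)cc1OC` stands highest of the two numbers measured so far, giving 70%. Within the data shown here, the only other compound measured, compound 1 `COc1cccc(/C=N/NC(=O)c2cccnc2Nc2cccc(C(F)(F)F)c2)c1`, gives 58.8% in this assay, and the step of a number 11.2 percentage points higher from compound 1 to compound 2 (beyond the scatter) is the one change that has been followed; it is modest but beyond the scatter.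

Compound 3 `CN(C)c1ccc(/C=N/NC(=O)c2cccnc2Nc2cccc(C(F)(F)F)c2)cc1` is the next compound to be tested. It differs from compound 2 by 4-(dimethylamino)phenyl in place of 3,4-dimethoxyphenyl on a carbon with a double bond to nitrogen. The step from compound 1 to compound 2 bears on this only loosely, since it too changed a group on the ring attached to the carbon with a double bond to nitrogen, and it moved the number by a modest amount. Among the measured compounds shown here, no measured step covers the exchange of one whole substituted ring for another, so the direction of the change cannot be read from the two compounds available.

Compound 3 is therefore expected to land near compound 2, with the estimated step of a number 6 percentage points lower from compound 2 to compound 3 (within the scatter) lying within the usual scatter. The estimate for compound 3 is 64%, with a range from 50% to 78%.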

Compound 3, a percentage reported as inhibition, in the whole organism at one dose (the size of the read-out at that dose, not a potency): 63.5%
The estimate for compound 3 lay 0.5 percentage points above the measured number; the range from low to high includes it.
By their numbers in this assay, from the lowest: compounds 1, 3 and 2 (each within the scatter of the next, the first and the last beyond it).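

In this assay, 4-(dimethylamino)phenyl in place of 3,4-dimethoxyphenyl gives a number 6.5 percentage points lower from compound 2 to compound 3 (within the scatter), and the same group in place of 3-methoxyphenyl gives a number 4.7 percentage points higher from compound 1 to compound 3 (within the scatter). This position on the carbon with a double bond to nitrogen therefore accepts a ring carrying a dimethylamino group instead of methoxy groups, and the read-out does not separate compound 3 from either of the other two compounds. No separate measurement bears on why the numbers fall as they do.

The compounds shown leave open how this position would respond to a ring carrying a carboxylic acid or a chlorine atom, or to a saturated cyclohexyl group in place of the ring. They also leave open what a plain phenyl ring with no substituent would give here.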